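This account rests on a few compounds, and the source may have more. Where it says the series, first, only, none or still open, it means among the compounds named here.

In a functional assay on HeLa cells (Homo sapiens) for cytotoxicity, read by ELISA, with a stated time of 4 days (on this read-out lower numbers stand for stronger inhibition and higher numbers for weaker inhibition), compound 1 `Clc1ccc(-c2cc(-c3ccoc3)cc(-c3ccco3)n2)s1` gives 22700 nM, compound 2 `Cc1ccc(-c2cc(-c3ccoc3)cc(-c3ccc(Cl)s3)n2)o1` gives 26500 nM and compound 3 `Cc1ccc(-c2cc(-c3ccoc3)cc(-c3ccc(Cl)s3)n2)cc1` gives 28700 nM. Compound 3 therefore stands level with the other two, all three values lying within the scatter of each other. Compound 4 `Clc1ccc(-c2cc(-c3ccoc3)cc(-c3ccccc3Cl)n2)s1` differs from compound 3 as follows: 2-chlorophenyl in place of 4-methylphenyl on an aromatic carbon, with 2-chlorophenyl in place of 4-methylphenyl next to the ring nitrogen. Three measured steps alter that same place: a 1.2-fold higher number from compound 1 to compound 2 (0.07 log units; within the scatter), a 1.3-fold higher number from compound 1 to compound 3 (0.10 log units; within the scatter) and a 1.1-fold higher number from compound 2 to compound 3 (0.03 log units; within the scatter). For the measured compounds named here, none leaves the scatter, although no measured compound carries 2-chlorophenyl. The expected change is a 1.3-fold lower number from compound 3 to compound 4 (0.12 log units; within the scatter), with no step beyond the scatter anticipated in this assay. Compound 4 is estimated at 22000 nM, within an expected range of 9000 nM to 45000 nM.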

Compound 4, half-maximal inhibitory concentration: 19000 nM
The estimate for compound 4 lay 1.2-fold (0.06 log units) above the measured number, within the range that was stated.
By their numbers in this assay, from the lowest: compounds 4, 1, 2 and 3 (each within the scatter of the next).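

In this assay the 2-chlorophenyl group next to the ring nitrogen brings no step beyond the scatter: a 1.5-fold lower number from compound 3 to compound 4 (0.18 log units; within the scatter), a 1.4-fold lower number from compound 2 to compound 4 (0.14 log units; within the scatter) and a 1.2-fold lower number from compound 1 to compound 4 (0.08 log units; within the scatter). A chlorine-bearing phenyl ring at this place thus joins 4-methylphenyl, 5-methylfuran-2-yl and furan-2-yl in leaving the number level. Nothing available explains this levelness. Going by these compounds, whether an amine or a carboxylic acid at this place would move the number beyond the scatter remains open. So does the effect of replacing the furan-3-yl group, which all four compounds share.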